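Swapping chloro for trifluoromethyl on the benzyl ring

The compounds below may be only part of what the source reports. "The series", "measured", "known", "first", "only" and "open" are said of these compounds alone.

Of the compounds shown here, three sharing one core have been tested in a functional assay on PC-9 cells (Homo sapiens) for inhibition, read by MTT assay, with a stated time of 72 h; a higher number here means a weaker inhibitor, a lower number a stronger inhibitor. Compound 1 `Cc1cc(Nc2cc(-c3ccccc3)[nH]n2)n2ncnc2n1` gives only the limit > 50000 nM. Compound 3 `CCCCCc1c(C)nc2nc(SCc3ccc(Cl)cc3)nn2c1Nc1cc(-c2ccccc2)[nH]n1` likewise gives only the limit > 50000 nM. For the measured compounds named here, compound 2 `Cc1cc(Nc2cc(-c3ccccc3)[nH]n2)n2nc(SCc3ccc(Cl)cc3)nc2n1` gives 6710 nM, the only true number in this assay so far. Putting (4-chlorobenzyl)sulfanyl in place of hydrogen gave an at least 7.4-fold lower number from compound 1 to compound 2 (0.87 log units; beyond the scatter), and putting pentyl in place of hydrogen gave an at least 7.4-fold higher number from compound 2 to compound 3 (0.87 log units; beyond the scatter); both steps run into (the limit of > 50000 nM in this assay, at which 2 of the 3 values shown sit). Compound 4 `Cc1cc(Nc2cc(-c3ccccc3)[nH]n2)n2nc(SCc3ccc(C(F)(F)F)cc3)nc2n1` differs from compound 2 by trifluoromethyl in place of chloro on an aromatic carbon. Going by the values given here, no measured step alters a group on that benzyl ring, so none bears directly on this swap, and no step beyond the scatter is expected in this assay; the estimated step is a 1.0-fold higher number from compound 2 to compound 4 (0.02 log units; within the scatter). Compound 4 is therefore expected to give about 7000 nM, most likely between 2500 nM and 20000 nM.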

Compound 4, half-maximal inhibitory concentration: 4240 nM
Beside the measured number, compound 4's estimate is 1.7-fold (0.22 log units) above it, and the stated range covers the measured number.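

Trifluoromethyl in place of chloro on the benzyl ring gives a 1.6-fold lower number from compound 2 to compound 4 (0.20 log units; within the scatter) in this assay, so this first measured change on that ring leaves the inhibition of PC-9 cells where it was. The position therefore accepts either of these two groups, and compound 4 keeps a true number rather than a limit. Nothing measured here gives a reason for this result. On these data alone, how an amine or a carboxylic acid at this place on the benzyl ring would behave remains open.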